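Cyclopropyl on the amide nitrogen: effect on whole-animal inhibition

The compounds below may be only part of what the source reports. "The series", "measured", "known", "first", "only" and "open" are said of these compounds alone.

Compound 1 `NC(=O)/C=C1\CCc2cc(F)c(F)cc21` and compound 2 `NC(=O)/C=C1\CCc2ccc(Br)cc21` share the acrylamide part but differ in the aromatic substitution; the difference between the two cores is not broken down here. In a functional assay on the whole organism with Mus musculus as the target, at a dose of 100 mg/kg by the intraperitoneal route (a lower number here means less inhibition, a higher number more inhibition at the dose given (going by the name of the read-out)), compound 1 gives 100% and compound 2 gives 100%; the two stand level at the digits recorded and together are the highest of the three numbers measured. Compound 3 `O=C(/C=C1\CCc2ccc(Br)cc21)NC1CC1` differs from compound 2 by cyclopropyl in place of hydrogen on an amide-type nitrogen. In this assay compound 3 gives 33%, and the step of a number 67 percentage points lower from compound 2 to compound 3 (beyond the scatter) is large and beyond the scatter. Compound 4 `O=C(/C=C1\CCc2cc(F)c(F)cc21)NC1CC1` has not yet been measured; it differs from compound 1 by cyclopropyl in place of hydrogen on an amide-type nitrogen. The place is the same in both pairs, so this is the same change, occurring twice among the four compounds. The expectation for compound 4 rests on one measured instance of the change only. By analogy with a number 67 percentage points lower from compound 2 to compound 3 (beyond the scatter), a step of about a number 65 percentage points lower from compound 1 to compound 4 (beyond the scatter) is expected. Compound 4 is therefore expected to give 35% in this assay, most likely between 10% and 65%.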

Compound 4, a percentage reported as inhibition, in the whole organism at one dose (the size of the read-out at that dose, not a potency): 50%
Beside the measured number, compound 4's estimate is 15 percentage points below it; the range from low to high includes it.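

In this assay, cyclopropyl in place of hydrogen on an amide-type nitrogen again goes with a lower number, a number 50 percentage points lower from compound 1 to compound 4 (beyond the scatter), so the direction of the change carries from the core of compound 2 to the core of compound 1 in the two pairs at hand. The size of the step does not carry over unchanged, and the loss depends on the core: the same change on two cores in this assay, a number 67 percentage points lower (beyond the scatter) from compound 2 to compound 3 and a number 50 percentage points lower (beyond the scatter) from compound 1 to compound 4, 17 percentage points apart, beyond the scatter of two such steps With two pairs at one dose, this does not show which feature of the aromatic substitution sets the size of the step, or how the change would behave on any further core.

On these data alone, it remains open whether other groups on the same nitrogen, such as methyl, cyclobutyl or a longer chain, lower the number as much as cyclopropyl does. As far as these compounds go, it also remains open how the step would run on a core carrying chlorine in place of bromine, which would help to show how far the size of the step follows the aromatic substitution.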